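A few compounds are considered here, and "the series" means these few. Any claim that something is new, unique, unknown or untested is made for them only; others in the source may bear on it.

Compound 1 `N#Cc1ccc(Nc2nc(Oc3ccnc4ccccc34)nc(N3CCN(c4ccccc4Cl)CC3)n2)cc1C(F)(F)F` was examined in a functional assay on DU-145 cells (Homo sapiens) for cytotoxicity, read by sulforhodamine B assay, with a stated time of 48 h; a higher number here means that more compound is tolerated, a lower number that less compound is tolerated. In this assay compound 1 gives > 100000 nM, and this is a limit of the assay rather than a measured number. Compound 2 `N#Cc1ccc(Nc2nc(Oc3ccnc4ccccc34)nc(N3CCN(C(c4ccccc4)c4ccc(Cl)cc4)CC3)n2)cc1C(F)(F)F` carries a different group in the same place. In this assay compound 2 gives > 100000 nM, again a limit. Compound 1 therefore stands at the limit of > 100000 nM in this assay, at which 2 of the 2 values shown sit, and no ordering between compound 1 and compound 2 can be drawn from these two readings. Compound 3 `N#Cc1ccc(Nc2nc(Oc3ccnc4ccccc34)nc(N3CCN(c4ccc(F)cc4)CC3)n2)cc1C(F)(F)F` differs from compound 1 by 4-fluorophenyl in place of 2-chlorophenyl on an amine nitrogen in a ring. For the measured compounds named here, no measured step of this kind exists here, so the expectation rests on the two limits alone. The step of a number no higher from compound 1 to compound 3 (the limit leaves the size open) is expected to be none beyond the scatter. Compound 3 is estimated at 100000 nM, with a range from 30000 nM to 300000 nM, and most probably the assay will again report only a limit.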

Compound 3, concentration lethal to 50% of the cells: > 100000 nM
Compound 3 was reported as a limit (the forecaster's own chance of this, stated with the estimate: 85%); the middle value sits exactly at the limit.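

For the compounds shown here, compound 1 and compound 3 are both reported only as limits, so no step between them can be read: the limit of > 100000 nM in this assay, at which 3 of the 3 values shown sit. The compounds shown leave open the actual lethal concentration of each in this assay, and whether changing the group on the amine nitrogen affects it at all.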